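Methoxy for chloro: the next step in the series

A few compounds are considered here, and "the series" means these few. Any claim that something is new, unique, unknown or untested is made for them only; others in the source may bear on it.

Measured so far in a functional assay on BV-2 cells (Mus musculus) for inhibition, read by Griess assay, with stated times of 3 h and 24 h; on this read-out higher numbers stand for weaker inhibition and lower numbers for stronger inhibition:
- compound 1 `O=S(=O)(/C=C/c1ccc(O)c(O)c1)CCc1ccccc1` gives 30600 nM
- compound 2 `O=S(=O)(/C=C/c1ccc(O)c(O)c1)CCCc1ccccc1` gives 10500 nM
- compound 3 `O=S(=O)(/C=C/c1ccc(O)c(O)c1)Cc1ccc(Cl)cc1` gives 11700 nM

Compound 3 sits close to compound 2, within the scatter, and both stand apart from compound 1; the gap to compound 3 is a 2.6-fold lower number from compound 1 to compound 3 (0.42 log units; beyond the scatter), a modest step. The other measured step, a 2.9-fold lower number from compound 1 to compound 2 (0.46 log units; beyond the scatter), is of similar size and concerns the saturated chain on the far side of the sulfonyl.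

Compound 4 `COc1ccc(CS(=O)(=O)/C=C/c2ccc(O)c(O)c2)cc1` differs from compound 3 by methoxy in place of chloro on an aromatic carbon, on a six-membered aromatic ring of carbon only, para to a large group. Among the compounds with values here, neither measured step bears on this change: both alter what sits on the saturated chain, and no measured pair varies a substituent on an aromatic ring. The data therefore give no direction for the swap, and the expected step in this assay is a 1.0-fold higher number from compound 3 to compound 4 (0.01 log units; within the scatter), not beyond the scatter. Compound 4 is estimated at 12000 nM in this assay, with a range from 5000 nM to 30000 nM.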

Compound 4, half-maximal inhibitory concentration: 11900 nM
The estimate for compound 4 lay 1.0-fold (0.00 log units) above the measured number; measured number inside the range.
By their numbers in this assay, from the lowest: compounds 2, 3 and 4 (each within the scatter of the next); then compound 1.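

In this assay, the swap of methoxy for chloro gives a 1.0-fold higher number from compound 3 to compound 4 (0.01 log units; within the scatter), so compound 3 and compound 4 cannot be told apart. Within the data shown here, this is the first measured change on the aromatic ring rather than on the saturated chain, and it shows that this aromatic carbon, para to a large group, accepts either group here, although methoxy brings one more heavy atom and one hydrogen-bond acceptor. Nothing available explains why the two groups read alike.

Still open, from the compounds shown here alone, is whether an amine or a carboxylic acid on this same carbon would stay within the scatter of compound 3, or would separate from it. Also open, going by these compounds, is how plain hydrogen at this place compares, and whether methoxy for chloro reads the same on a longer chain.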